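Carboxy to 2-methoxyethoxy on compound 2

A few compounds are considered here, and "the series" means these few. Any claim that something is new, unique, unknown or untested is made for them only; others in the source may bear on it.

In a physicochemical assay for solubility, read by spectrophotometry, using the shake flask method, with a stated time of 2 days, at pH 6.5 (on this read-out lower numbers stand for lower solubility and higher numbers for higher solubility), compound 2 `O=C(O)c1cccc(Oc2cccc3nc(-c4cn(-c5ccc(O)c(F)c5)nn4)ccc23)c1` gives 47.2 ug/mL and stands second highest of three numbers. Compound 1 `Oc1ccc(-n2cc(-c3ccc4cc(OCC5CCCCO5)ccc4n3)nn2)cc1` reads lower (3.4 ug/mL) and compound 3 `O=C(O)COc1ccc2nc(-c3cn(-c4ccccc4)nn3)ccc2c1` reads higher (1050 ug/mL), both gaps beyond the scatter. Compound 4 `COCCOc1cccc(Oc2cccc3nc(-c4cn(-c5ccc(O)c(F)c5)nn4)ccc23)c1` carries 2-methoxyethoxy in place of carboxy on an aromatic carbon and is otherwise unchanged. Among the measured compounds shown here, no measured pair isolates this change. For the measured compounds named here, the only guide is compound 1, which has no carboxy and reads 3.4 ug/mL in this assay as the lowest of the three. A downward step beyond the scatter is therefore expected a 12-fold lower number from compound 2 to compound 4 (1.07 log units; beyond the scatter) in this estimate. Compound 4 is estimated at 4 ug/mL with an expected range of 1 ug/mL to 15 ug/mL for now.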

Compound 4, solubility: 6.1 ug/mL
Estimate against measurement, compound 4: 1.5-fold (0.18 log units) below, within the range that was stated.
By their numbers in this assay, from the lowest: compounds 1 and 4 (each within the scatter of the next); then compound 2; then compound 3.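

In this assay, among the compounds shown here, 2-methoxyethoxy in place of carboxy on an aromatic carbon gives a 7.7-fold lower number from compound 2 to compound 4 (0.89 log units; beyond the scatter) and is the first step to isolate a single change. At this place, the 3-(2-methoxyethoxy)phenyl group, without a hydrogen-bond donor, does not keep the number given by the 3-carboxyphenyl group. Nothing measured here gives a cause for the step.

On these data alone, whether an amine or a primary amide at this place would read nearer compound 2 or compound 4 remains open. Also open, as far as these compounds go, is whether the same change gives a similar step on the core of compound 3.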